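Swapping the aryl group on the double-bonded chain carbon

A few compounds are considered here, and "the series" means these few. Any claim that something is new, unique, unknown or untested is made for them only; others in the source may bear on it.

Measured in a functional assay on DU-145 cells (Homo sapiens) for inhibition, read by trypan blue exclusion, with a stated time of 96 h; a lower number here means a stronger inhibitor of growth, a higher number a weaker inhibitor of growth:
- compound 1 `COc1cc(/C=C(/Sc2ccc(Br)cc2)C(=O)c2ccc(Br)cc2)ccc1O`: 1000 nM
- compound 2 `O=C(/C(=C\c1ccc(Br)c(O)c1)Sc1ccc(Br)cc1)c1ccc(Br)cc1`: 1000 nM
- compound 3 `Nc1c(Br)cc(Br)cc1/C=C(/Sc1ccc(Br)cc1)C(=O)c1ccc(Br)cc1`: > 100000 nM

Compound 3 gives only a limit, > 100000 nM, and no number. Compound 4 `O=C(/C(=C\c1ccc(I)cc1)Sc1ccc(Br)cc1)c1ccc(Br)cc1` carries 4-iodophenyl in place of 2-amino-3,5-dibromophenyl (4-iodophenyl in place of 2-amino-3,5-dibromophenyl on a double-bonded chain carbon bound to a double-bonded chain carbon). Two large measured steps at this place bear on the change: an at least 100-fold higher number from compound 1 to compound 3 (2.00 log units; beyond the scatter) and an at least 100-fold higher number from compound 2 to compound 3 (2.00 log units; beyond the scatter). A third exchange at the same place gave no change at the digits printed from compound 1 to compound 2 (within the scatter). Going by the values given here, no measured compound carries 4-iodophenyl, so the transfer is uncertain. A large step to a lower number is expected in this assay. The estimated step is an at least 50-fold lower number from compound 3 to compound 4 (1.69 log units; beyond the scatter). For compound 4 the expected value is 2000 nM, with an estimated range of 300 nM to 20000 nM.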

Compound 4, concentration for 50% growth inhibition: 1000 nM
Beside the measured number, compound 4's estimate is 2.0-fold (0.30 log units) above it; the measured number falls inside the stated range.
By their numbers in this assay, from the lowest: compounds 1, 2 and 4 (each within the scatter of the next). At a limit, above all of these: compound 3.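

In this assay, 4-iodophenyl at this place gives an at least 100-fold lower number from compound 3 to compound 4 (2.00 log units; beyond the scatter). Compound 3 stands at a limit, not a number: the limit of > 100000 nM in this assay, at which 1 of the 4 values shown sits.

With no hydrogen-bond donor in the entering group, the series still shows no change at the digits printed from compound 2 to compound 4 (within the scatter) and no change at the digits printed from compound 1 to compound 4 (within the scatter), so among compounds 1, 2 and 4 a hydroxyl on this aryl group is not required.

Which part of 2-amino-3,5-dibromophenyl goes with the high limit stays open, since the amino group and both bromines leave together. A 2-aminophenyl or an unsubstituted phenyl group at this place would separate these contributions.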